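Swapping the Aryl Group on a Kinase Binder

The compounds below may be only part of what the source reports. "The series", "measured", "known", "first", "only" and "open" are said of these compounds alone.

Going by the values given here, compound 2 `CCCS(=O)(=O)Nc1ccc(F)c(C(=O)c2n[nH]c3ncc(-c4cccc(C)c4)cc23)c1F` gives 15% in an assay for binding affinity to dual specificity mitogen-activated protein kinase kinase 4 (Homo sapiens), read by KINOMEscan, tested at 100 nM (a higher number here means a weaker effect of the compound at the concentration tested, a lower number a stronger effect), the higher of the two numbers measured so far; compound 1 `CCCS(=O)(=O)Nc1ccc(F)c(C(=O)c2n[nH]c3ncc(-c4ccccc4F)cc23)c1F` gives 2%. Compound 3 `CCCS(=O)(=O)Nc1ccc(F)c(C(=O)c2n[nH]c3ncc(-c4ccc(OC)cc4)cc23)c1F` differs from compound 2 in a single place: 4-methoxyphenyl in place of 3-methylphenyl on an aromatic carbon. Among the compounds with values here, the only measured step at the same aromatic carbon, a number 13 percentage points higher from compound 1 to compound 2 (beyond the scatter), shows that exchanging this aromatic group shifts the read-out modestly, but it compares different groups and offers no direction for 4-methoxyphenyl. A modest shift either way, or none beyond the scatter, is therefore expected. Compound 3 is estimated at 15%, within 3% to 40%. The expected step is no change at the digits printed from compound 2 to compound 3 (within the scatter).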

Compound 3, a percentage reported as activity, at one concentration (the size of the read-out at that concentration, not a potency): 4.2%
Compound 3: the middle estimate sits 10.8 percentage points above what was measured; low and high end bracket the measured number.
By their numbers in this assay, from the lowest: compounds 1 and 3 (each within the scatter of the next); then compound 2.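

In this assay, a change of aromatic group at this carbon can also lower the number: a number 10.8 percentage points lower from compound 2 to compound 3 (beyond the scatter). The two groups compared with 4-methoxyphenyl therefore give different pictures, as a number 2.2 percentage points higher from compound 1 to compound 3 (within the scatter), so 4-methoxyphenyl and 2-fluorophenyl cannot be told apart here, while 3-methylphenyl stands apart from both. Nothing available explains why these aryl groups differ. The compounds shown leave open how this position responds to groups other than a substituted phenyl, such as a simple amine or a morpholine ring. They also leave open whether a carboxylic acid on the phenyl ring would be tolerated.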